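Swapping the amine on a sulfonyl-linked aryl ether

A few compounds are considered here, and "the series" means these few. Any claim that something is new, unique, unknown or untested is made for them only; others in the source may bear on it.

compound 1 `CC(C)(C)NCCCOc1ccc(S(=O)(=O)c2c(C(C)(C)C)cn3ccccc23)cc1` gives 443 nM
compound 2 `CCCCN(CCCC)CCCOc1ccc(S(=O)(=O)c2c(CC)cn3ccccc23)cc1` gives 31.3 nM
compound 3 `CCCCN(CCCC)CCCCOc1ccc(S(=O)(=O)c2c(CC)cn3ccccc23)cc1` gives 33.3 nM

In a functional assay (aorta) with Rattus norvegicus as the target (a higher number here means a weaker inhibitor, a lower number a stronger inhibitor), compound 3 gives 33.3 nM. This lies within the scatter of compound 2 and well below compound 1. The next compound is compound 4 `CCc1cn2ccccc2c1S(=O)(=O)c1ccc(OCCCNC(C)(C)C)cc1`, and the change is (tert-butyl)amino in place of (dibutylamino)methyl on a saturated chain carbon, three bonds along the chain from an oxygen on an aromatic ring.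

Within the data shown here, one measured step bears directly on this change: a 1.1-fold higher number from compound 2 to compound 3 (0.03 log units; within the scatter). It lies within the scatter, so the dibutylamino to (dibutylamino)methyl part of the change offers no reason to expect a shift. Among the measured compounds shown here, the data hold no step that isolates the arrival of (tert-butyl)amino. That group occurs only in compound 1, at 443 nM, and the core of compound 1 differs from that of compound 4. Its value still points towards a higher number, though probably not all the way.

The expected change is a 5.4-fold higher number from compound 3 to compound 4 (0.73 log units; beyond the scatter), which would be a moderate weakening. The estimated value for compound 4 is 180 nM, with an expected range of 50 nM to 600 nM.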

Compound 4, half-maximal inhibitory concentration: 413 nM
Beside the measured number, compound 4's estimate is 2.3-fold (0.36 log units) below it, and the stated range covers the measured number.
By their numbers in this assay, from the lowest: compounds 2 and 3 (each within the scatter of the next); then compounds 4 and 1 (each within the scatter of the next).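

In this assay, the amine proves to be the part of this position that matters: (tert-butyl)amino in place of dibutylamino gives a 13-fold higher number from compound 2 to compound 4 (1.12 log units; beyond the scatter), and the step from the longer (dibutylamino)methyl chain is similar, at a 12-fold higher number from compound 3 to compound 4 (1.09 log units; beyond the scatter). Ethyl in place of tert-butyl on the aromatic carbon gives a 1.1-fold lower number from compound 1 to compound 4 (0.03 log units; within the scatter), which lies within the scatter, so among these compounds that exchange does not move the number, and the high value of compound 1 is matched by compound 4 with ethyl. No measurement here accounts for the size of the amine step.

On these data alone, it remains open where intermediate amines such as diethylamino or dipropylamino would fall between these values. As far as these compounds go, it is also open whether tert-butyl on the aromatic carbon would leave a dibutylamino compound unchanged, as it does with (tert-butyl)amino.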